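Mirror image of a stable compound, half-life still unknown

This account rests on a few compounds, and the source may have more. Where it says the series, first, only, none or still open, it means among the compounds named here.

In an ADME assay on Caco-2 cells (Homo sapiens) for metabolic stability, read by HPLC, with a stated time of 12 h (a lower number here means that the compound disappears faster, a higher number that the compound lasts longer), compound 2 `O=C(N[C@H](CO)C(=O)O)[C@@H]1C[C@H](O)CN1` gives > 12 h as a limit of the assay, not a number. Compound 1 `O=C(O)[C@@H](CO)NC(=O)[C@H]1C[C@H](O)CN1` gives > 12 h as a limit too. Compound 3 `O=C(O)[C@H](CO)NC(=O)[C@H]1C[C@@H](O)CN1` is new, and the change is this: the two compounds have the same atoms and bonds and differ only in configuration as drawn: 3 of 3 stereo elements differ (all stereocentres are inverted: mirror images); a stereocentre at a saturated chain carbon is drawn R in compound 2 and S in compound 3; a stereocentre at a saturated ring carbon is drawn S in compound 2 and R in compound 3; a stereocentre at a saturated ring carbon is drawn S in compound 2 and R in compound 3 and nothing else. For the measured compounds named here, one measured step bears on it, a step that the two limits leave unreadable from compound 1 to compound 2 and this rests on the fact that compounds 1 and 2 differ only in the configuration as drawn as the only difference. Because of the limit of > 12 h in this assay, at which 2 of the 2 values shown sit, no step beyond the scatter is expected. The expected change is a step that the limit leaves unreadable from compound 2 to compound 3 as an estimate without clear direction. Compound 3 is estimated at 15 h with a range from 9 h to 30 h and may well report only a limit.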

Compound 3, half-life: > 12 h
Compound 3: no number, only a limit (the forecaster's own chance of this, stated with the estimate: 85%); the middle value does not contradict the limit.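

Compound 3 gives > 12 h, a limit and not a number. For the compounds shown here, with compound 1 and compound 2 also reported only as limits, no step among the three compounds can be read. From the compounds shown here alone, their actual half-lives remain open, as does whether configuration changes them at all.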